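A few compounds are considered here, and "the series" means these few. Any claim that something is new, unique, unknown or untested is made for them only; others in the source may bear on it.

Working notes on the series. The shared core of compound 1 `O=C(O)c1cc2cc(-c3ccc(Cl)cc3)ccc2n1O` carries a chlorophenyl group; compound 2 `O=C(O)c1cc2cc(-c3ccc(F)cc3)ccc2n1O` differs by fluoro in place of chloro on an aromatic carbon. Compound 3 `O=C(O)c1cc2ccc(-c3ccc(Cl)cc3)cc2n1O` has the same atoms as compound 1, joined differently; the difference between the two cores is not broken down here. Compound 4 `O=C(O)c1cc2ccc(-c3ccc(F)cc3)cc2n1O` is not yet measured and differs from compound 3 by fluoro in place of chloro on an aromatic carbon, the same kind of change as that from compound 1 to compound 2, with the two place descriptions matching word for word.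

In an ADME assay on HS27 cells (Homo sapiens) for antiproliferative activity, read by sulforhodamine B assay, with a stated time of 48 h (on this read-out higher numbers stand for weaker inhibition and lower numbers for stronger inhibition), compound 1 gives only a limit of the assay, > 100000 nM. In this assay compound 2 likewise gives a limit, > 100000 nM. In this assay compound 3 also gives a limit, > 100000 nM. The step that the two limits leave unreadable from compound 1 to compound 2 is therefore not readable, since (the limit of > 100000 nM in this assay, at which 3 of the 3 values shown sit).

For compound 4 the same kind of change is expected to leave the result at the limit, a step that the limit leaves unreadable from compound 3 to compound 4, resting on compound 3 at > 100000 nM and on compound 1 and compound 2 both sitting at the limit. Compound 4 is expected to read about 150000 nM, between 100000 nM and 600000 nM.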

Compound 4, half-maximal inhibitory concentration: > 100000 nM
Compound 4 was reported as a limit (the forecaster's own chance of this, stated with the estimate: 90%); the middle value is on the limit's open side.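

No step from compound 3 to compound 4 can be read, since both compounds sit at a limit in this assay: the limit of > 100000 nM in this assay, at which 4 of the 4 values shown sit.

The compounds shown leave open how chloro and fluoro, or the two cores, compare in this read-out.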